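Swapping pyrrolidin-1-yl for difluoromethoxy on a shared core

This account rests on a few compounds, and the source may have more. Where it says the series, first, only, none or still open, it means among the compounds named here.

Compound 1 `COc1nc(C)c(Nc2nc(Cl)cn([C@H](C)C3CC3)c2=O)cc1C`: 55%
Compound 2 `Cc1cc(Nc2nc(Cl)cn([C@H](C)C3CC3)c2=O)c(C)nc1N(C)C`: 29%
Compound 3 `Cc1cc(Nc2nc(Cl)cn([C@H](C)C3CC3)c2=O)c(C)nc1N1CCCC1`: 26%

These compounds share one core and differ in a single group. In an ADME assay on microsomes from liver (Homo sapiens) for metabolic stability, with a stated time of 10 min (a higher number here means that more of the compound is left, a lower number that less of the compound is left), compound 3 gives 26% and stands level with compound 2 at 29% within the scatter, while compound 1 at 55% lies clearly higher.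

Compound 4 `Cc1cc(Nc2nc(Cl)cn([C@H](C)C3CC3)c2=O)c(C)nc1OC(F)F` has not been measured yet. It differs from compound 3 in one place (difluoromethoxy in place of pyrrolidin-1-yl on an aromatic carbon): difluoromethoxy in place of pyrrolidin-1-yl on an aromatic carbon.

Among the compounds with values here, three measured steps bear on this change. Replacing methoxy gave a number 26 percentage points lower from compound 1 to compound 2 (beyond the scatter) with dimethylamino and a number 29 percentage points lower from compound 1 to compound 3 (beyond the scatter) with pyrrolidin-1-yl. Between those two amine groups the data show a number 3 percentage points lower from compound 2 to compound 3 (within the scatter) and so no real difference. Within the data shown here, no compound with fluorine in this group has been measured, which leaves the transfer uncertain. Still, compound 1 at 55% is the closest comparison, since its group is also joined through oxygen. A rise in this assay of about the same size as those two drops, beyond the scatter, is therefore expected (a number 32 percentage points higher from compound 3 to compound 4 (beyond the scatter)). Compound 4 is estimated at 58% (expected range 38% to 78%).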

Compound 4, percent of the compound remaining: 86%
For compound 4 the middle estimate is 28 percentage points below the measured one; measured number outside the range, above it.
By their numbers in this assay, from the lowest: compounds 3 and 2 (each within the scatter of the next); then compound 1; then compound 4.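

In this assay the change from a ring amine to difluoromethoxy gives a number 60 percentage points higher from compound 3 to compound 4 (beyond the scatter) and the change from the open-chain amine gives a number 57 percentage points higher from compound 2 to compound 4 (beyond the scatter), so this place on the aromatic ring, next to the ring nitrogen, can move the value across much of the scale with one group. The earlier compounds shown here left open whether simply having an oxygen joined to the ring set the upper level, and the step with difluoromethyl in place of methyl on that oxygen answers this: it gives a number 31 percentage points higher from compound 1 to compound 4 (beyond the scatter), which puts compound 4 clearly above all three others even though the oxygen stays in place. Nothing available here explains why the swap to difluoromethyl on the oxygen has so large an effect.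

On these data alone, whether trifluoromethoxy or monofluoromethoxy would keep, raise or lower the value of compound 4 stays open. So does the behaviour of a longer chain on the oxygen, such as ethoxy, or of a group joined directly through carbon, such as difluoromethyl on the ring itself.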